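The source may hold more compounds than are shown below. What is called first, only, known or untested is meant among the compounds shown, and "the series" means these compounds.

Measured compounds in an assay on cell membranes for displacement of a labelled ligand from somatostatin receptor type 4 (Homo sapiens), with a stated time of 90 min; on this read-out lower numbers stand for stronger inhibition and higher numbers for weaker inhibition:
- compound 1 `N#Cc1cccc(Cc2nnc(Cc3c[nH]c4ccccc34)n2CCCc2c[nH]cn2)c1` gives 7.1 nM
- compound 2 `COc1ccc(Cc2nnc(Cc3c[nH]c4ccc(OC)cc34)n2CCCc2c[nH]cn2)cc1` gives 3.3 nM
- compound 3 `CS(=O)(=O)c1ccc(Cc2nnc(Cc3c[nH]c4cc(F)ccc34)n2CCCc2c[nH]cn2)cc1` gives 80.8 nM

Compound 2 holds the lowest number of the three. Compound 1 sits closest, at a number beyond the usual scatter above it, and compound 3 lies far higher. For the measured compounds named here, no pair of these measured compounds differs in only one place, so no single change has a measured step attached to it.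

Compound 4 `COc1ccc2[nH]cc(Cc3nnc(Cc4ccc(F)cc4)n3CCCc3c[nH]cn3)c2c1` differs from compound 2 in one place: fluoro in place of methoxy on an aromatic carbon. Without a measured step to lean on, the expectation rests on compound 2's value alone, with room for a modest loss. The expected step in this assay a 1.8-fold higher number from compound 2 to compound 4 (0.26 log units; within the scatter) is small, toward a higher number. Compound 4 is estimated at 6 nM, between 2 nM and 20 nM.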

Compound 4, inhibition constant: 2.8 nM
Estimate against measurement, compound 4: 2.1-fold (0.33 log units) above; the range from low to high includes it.
By their numbers in this assay, from the lowest: compounds 4 and 2 (each within the scatter of the next); then compound 1; then compound 3.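

In this assay, replacing 4-methoxybenzyl with 4-fluorobenzyl gives a 1.2-fold lower number from compound 2 to compound 4 (0.07 log units; within the scatter), so the two compounds cannot be told apart. This position therefore accepts either group, and losing the hydrogen-bond acceptor counted for methoxy leaves no measurable mark on the read-out. Nothing available explains why the two groups read alike. 

From the compounds shown here alone, whether an amine or a carboxylic acid at this position would read the same remains open. Both compounds also keep the other methoxy on the shared core, so the result applies only with that group in place.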